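Moving a substituent on the benzamide ring of compound 2

The compounds below may be only part of what the source reports. "The series", "measured", "known", "first", "only" and "open" are said of these compounds alone.

Measured compounds:
compound 1, `O=C(NCc1ccc(CNS(=O)(=O)c2ccccc2)cc1)c1cccc(F)c1`: 100 nM
compound 2, `Cc1ccc(S(=O)(=O)NCc2ccc(CNC(=O)c3ccc(Cl)cc3)cc2)cc1`: 10 nM
compound 3, `O=C(NCc1ccc(CNS(=O)(=O)c2ccccc2)cc1)c1ccccc1F`: 1000 nM

In an assay on MDA-MB-231 cells for binding affinity to C-X-C chemokine receptor type 4 (Homo sapiens), read by immunofluorescence and microscopy, with stated times of 10 min and 30 min (on this read-out higher numbers stand for an effect only at larger amounts of compound and lower numbers for an effect already at smaller amounts), compound 2 gives the lowest number of the three. Compound 1 gives 100 nM and compound 3 gives 1000 nM, so compound 2 stands well apart from both, with compound 1 the nearer of the two.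

Compound 4, `Cc1ccc(S(=O)(=O)NCc2ccc(CNC(=O)c3ccccc3C)cc2)cc1`, has not yet been measured in this assay. It differs from compound 2 in one place: 2-methylphenyl in place of 4-chlorophenyl on a carbonyl carbon. Going by the values given here, the one measured step that bears on this change is the one between compound 1 and compound 3, where the fluorine on the ring attached to the carbonyl carbon moves from the 3-position to the 2-position: a 10-fold higher number from compound 1 to compound 3 (1.00 log units; beyond the scatter). Among the compounds with values here, the change from compound 2 to compound 4 likewise moves the only ring substituent to the 2-position, although here the group itself also changes, from chlorine to methyl, for which no measured pair exists. On the strength of the step from compound 1 to compound 3 the expectation is a higher number for compound 4, by about the same size: a 10-fold higher number from compound 2 to compound 4 (1.00 log units; beyond the scatter). Compound 4 is therefore estimated at 100 nM, with a range from 30 nM to 400 nM.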

Compound 4, effective concentration (reported as EC, without a stated level of effect): 100 nM
Estimate against measurement, compound 4: no gap at the digits printed; low and high end bracket the measured number.
By their numbers in this assay, from the lowest: compound 2; then compounds 1 and 4 (each within the scatter of the next); then compound 3.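

In this assay, going by these compounds alone, the new step reads a 10-fold higher number from compound 2 to compound 4 (1.00 log units; beyond the scatter), which gives the first measured change at this carbonyl carbon on the core of compound 2, and it takes the series beyond fluorine to a change of both the substituent and its place on the ring. Within the data shown here, until now the only step at this position was a 10-fold higher number from compound 1 to compound 3 (1.00 log units; beyond the scatter), on the core of compound 1, so the two steps now show a higher number of the same printed size on two different cores, each time with a 2-substituted ring entering, though this pattern rests on these two pairs alone and the new step alters the group as well as its place. Nothing measured here accounts for the higher number in either pair.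

The compounds shown leave open whether the rise goes with the 2-position or with the change from chlorine to methyl, a question on which a 2-chlorophenyl or a 4-methylphenyl group on the same carbonyl carbon of the core of compound 2 would bear directly. Also open, from the compounds shown here alone, is how this position would respond to a ring carrying an amine or a carboxylic acid, or to a longer chain in place of the ring.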